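Predicting Compound 4 from Three Measured Neighbours

A few compounds are considered here, and "the series" means these few. Any claim that something is new, unique, unknown or untested is made for them only; others in the source may bear on it.

Three compounds have been measured in an assay on isolated protein for inhibition of Amine oxidase [flavin-containing] A (Homo sapiens), read by fluorescence, with a stated time of 15 min; a higher number here means a weaker inhibitor, a lower number a stronger inhibitor:
compound 1 `COc1ccc(/C=C/c2cc(OC)cc(OC)c2/C=C/C(=O)c2cc3ccccc3oc2=O)cc1`, giving 41700 nM
compound 2 `COc1ccc(/C=C/c2cc(OC)cc(OC)c2/C=C/C(=O)c2cc3cc(F)ccc3oc2=O)cc1`, giving 44300 nM
compound 3 `COc1ccc(/C=C/c2cc(OC)cc(OC)c2/C=C/C(=O)c2cc3ccc(C)cc3oc2=O)cc1`, giving 58200 nM

Compound 1 holds the lowest of the three numbers, yet its neighbours sit close: the step of a 1.1-fold higher number from compound 1 to compound 2 (0.03 log units; within the scatter) and the step of a 1.4-fold higher number from compound 1 to compound 3 (0.14 log units; within the scatter) both fall within the scatter of repeated measurements, so no ranking among the three can be read from these values.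

Compound 4 `COc1ccc(/C=C/c2cc(OC)cc(OC)c2/C=C/C(=O)c2cc3cccc(C)c3oc2=O)cc1` differs from compound 1 by a single change, (methyl in place of hydrogen on an aromatic carbon). Among the compounds with values here, the step that bears most directly on it is the one from compound 1 to compound 3, where a methyl entered at a different aromatic carbon of the same fused ring and gave a 1.4-fold higher number from compound 1 to compound 3 (0.14 log units; within the scatter), a movement inside the scatter. The fluoro step a 1.1-fold higher number from compound 1 to compound 2 (0.03 log units; within the scatter) likewise stayed inside the scatter. Nothing here shows a small substituent on this ring shifting the number beyond the noise, so for compound 4 the expected step is a 1.2-fold higher number from compound 1 to compound 4 (0.08 log units; within the scatter), essentially none beyond the scatter. Compound 4 is therefore estimated at 50000 nM, with a range from 25000 nM to 100000 nM.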

Compound 4, half-maximal inhibitory concentration: > 60000 nM
Compound 4: only a limit was reported; the forecaster's own chance of this, stated with the estimate: 10%; at least 1.2-fold (0.07 log units) between middle value and limit.
By their numbers in this assay, from the lowest: compounds 1, 2 and 3 (each within the scatter of the next). At a limit, above all of these: compound 4.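

Compound 4, with its methyl on an aromatic carbon ortho to a fused ring, gave only a limit and no full number in this assay: the limit of > 60000 nM in this assay, at which 1 of the 4 values shown sits. Its steps are therefore floors and not sizes: the change itself gives an at least 1.4-fold higher number from compound 1 to compound 4 (0.15 log units; that floor lies within the scatter), and the comparisons with the other two compounds give an at least 1.3-fold higher number from compound 2 to compound 4 (0.13 log units; that floor lies within the scatter) and an at least 1.0-fold higher number from compound 3 to compound 4 (0.01 log units; that floor lies within the scatter). What this adds is that, among the three substituted compounds shown, only this placement of a small group ran into the limit, while every floor stays within the scatter, so the methyl here may have changed the number greatly or hardly at all.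

Going by these compounds, the true number for compound 4 remains open, and so does whether a methyl at this carbon really gives a weaker inhibitor than a methyl at the carbon carried by compound 3. Also open, on these data alone, is how a different group at this same carbon, such as an amine or a carboxylic acid, would read in this assay.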